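The source may report more compounds than this note shows. Statements on the series, on what has been measured and on what is new or still open speak of the compounds shown alone.

Compound 1 `COc1cc2cc(Oc3ccc(NC(=O)Nc4cccc(C(F)(F)F)c4)cc3)c(C)nc2cc1OC` gives 22200 nM in a functional assay on HCT-15 cells (Homo sapiens) for inhibition, read by sulforhodamine B assay, with a stated time of 48 h; on this read-out lower numbers stand for stronger inhibition of growth and higher numbers for weaker inhibition of growth.
Compound 2 `COc1cc2cc(Oc3ccc(NC(=O)Nc4ccc(Cl)c(C(F)(F)F)c4)cc3)c(C)nc2cc1OC` gives 4860 nM in this assay.

Among the compounds with values here, of the two numbers measured so far, compound 2 holds the lower one, and its only neighbour is compound 1. Within the data shown here, the single measured step, a 4.6-fold lower number from compound 1 to compound 2 (0.66 log units; beyond the scatter), came with chloro in place of hydrogen on an aromatic carbon, so adding that chloro went together with a clearly stronger inhibition of growth.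

Compound 3 `COc1cc2cc(Oc3ccc(NC(=O)Nc4ccc(Cl)c(Cl)c4)cc3)c(C)nc2cc1OC` has not yet been measured. It differs from compound 2 by chloro in place of trifluoromethyl on an aromatic carbon. Among the measured compounds shown here, no measured step exchanges a trifluoromethyl for a chloro, so the one step at hand bears on this change only loosely: it shows that a chloro on this ring is well tolerated, but says nothing about removing the trifluoromethyl. The expectation for this assay is therefore a small shift, most likely a slightly higher number, close to the scatter. Compound 3 is estimated to give about 7000 nM, within a range from 2500 nM to 20000 nM, which means an expected step of a 1.4-fold higher number from compound 2 to compound 3 (0.16 log units; within the scatter).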

Compound 3, concentration for total growth inhibition: > 100000 nM
Compound 3 was reported as a limit; the forecaster's own chance of this, stated with the estimate: 5%; middle value at least 14-fold (1.15 log units) from the limit.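

In this assay compound 3 stands at a limit and not at a number: the limit of > 100000 nM in this assay, at which 1 of the 3 values shown sits. Exchanging the trifluoromethyl for a chloro at this ring position, ortho to a chloro group, gave an at least 20-fold higher number from compound 2 to compound 3 (1.31 log units; beyond the scatter) and so turned the most active of the three compounds into the least active, which shows that the two groups are far from interchangeable here. The step of an at least 4.5-fold higher number from compound 1 to compound 3 (0.65 log units; beyond the scatter) adds something the earlier pair could not show: the gain of a 4.6-fold lower number from compound 1 to compound 2 (0.66 log units; beyond the scatter) came with the trifluoromethyl in place, whereas the 3,4-dichlorophenyl compound falls behind even the 3-(trifluoromethyl)phenyl compound that has no chloro at all.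

The compounds shown leave open how a methyl, a methoxy or a nitrile at this position would read, and so which feature of the trifluoromethyl matters for growth inhibition. The true value of compound 3 also remains unknown, which means the full size of the loss cannot be read, and nothing here gives its cause.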